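The compounds below may be only part of what the source reports. "The series", "measured", "known", "first", "only" and "open" are said of these compounds alone.

Compound 1 `CC(=O)Oc1ccccc1C(=O)OCOC(=O)c1ccc([S+]([O-])CCCO[N+](=O)[O-])cc1` was tested in an ADME assay on a cell-free system (serum, Homo sapiens) for metabolic stability, read by HPLC, tested at 250 uM; on this read-out higher numbers stand for a longer-lived compound and lower numbers for a shorter-lived compound. In this assay compound 1 gives < 0.0167 h, which is a limit of the assay rather than a number. Compound 2 `CC(=O)Oc1ccccc1C(=O)OCOC(=O)CCCCCCO[N+](=O)[O-]` gives < 0.0167 h, also a limit. Compound 3 `CC(=O)Oc1ccccc1C(=O)OCOC(=O)CCCCCO[N+](=O)[O-]` gives < 0.0167 h, again a limit. The step that the two limits leave unreadable from compound 2 to compound 3 therefore cannot be sized, because of the limit of < 0.0167 h in this assay, at which 3 of the 3 values shown sit. Compound 4 `CC(=O)Oc1ccccc1C(=O)OCOC(=O)c1ccc(CCCO[N+](=O)[O-])cc1` differs from compound 1 in one place: a group of 7 heavy atoms (3 carbon, 1 nitrogen, 3 oxygen; no ring) in place of a group of 9 heavy atoms (3 carbon, 1 nitrogen, 4 oxygen, 1 sulfur; no ring), on an aromatic carbon, the entering group being a 3-(nitrooxy)propyl on an aromatic carbon, para to a large group. Among the measured compounds shown here, no measured step bears directly on this change; all that is known is that every measured compound sits at the same limit. The step that the limit leaves unreadable from compound 1 to compound 4 is therefore expected to be none beyond the scatter. Compound 4 is expected to give 0.01 h, between 0.003 h and 0.03 h.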

Compound 4, half-life: 0.0317 h
For compound 4 the middle estimate is 3.2-fold (0.50 log units) below the measured one, outside the stated range (above it).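

Among the compounds shown here, compound 4 is the first compound here to give a number rather than a limit in this assay. Putting 3-(nitrooxy)propyl in place of the sulfur-bearing group on this aromatic carbon gives an at least 1.8-fold higher number from compound 1 to compound 4 (0.27 log units; that floor lies within the scatter). The full size of this step stays unread because one end of it is a limit: the limit of < 0.0167 h in this assay, at which 3 of the 4 values shown sit.

The compounds shown leave open how much of the step comes from losing the sulfur and its oxygen. They also leave open how a longer chain or an amine at this place would read in this assay.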